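The source may hold more compounds than are shown below. What is called first, only, known or untested is meant among the compounds shown, and "the series" means these compounds.

Measured so far in a functional assay on Ehrlich cells (Mus musculus) for cytotoxicity, read by MTT assay, with a stated time of 48 h; a lower number here means a stronger inhibitor, a higher number a weaker inhibitor:
compound 1 `COc1ccc(C(=O)c2cc(C)ccc2OCC(=O)NNC(=O)c2cc3ccccc3oc2=O)cc1`: 38400 nM
compound 2 `Cc1ccc(OCC(=O)NNC(=O)c2cc3ccccc3oc2=O)c(C(=O)c2ccccc2Br)c1`: 8000 nM
compound 3 `Cc1ccc(OCC(=O)NNC(=O)c2cc3ccccc3oc2=O)c(C(=O)c2ccccc2)c1`: 78400 nM

Compound 2 stands lowest of the three; the steps of a 4.8-fold lower number from compound 1 to compound 2 (0.68 log units; beyond the scatter) and a 9.8-fold higher number from compound 2 to compound 3 (0.99 log units; beyond the scatter) are both beyond the scatter. Compound 4 `Cc1ccc(OCC(=O)NNC(=O)c2cc3ccccc3oc2=O)c(C(=O)c2ccccc2Cl)c1` differs from compound 2 by chloro in place of bromo on an aromatic carbon. The step that bears on it is a 9.8-fold higher number from compound 2 to compound 3 (0.99 log units; beyond the scatter), where the bromo is removed altogether; the step of a 4.8-fold lower number from compound 1 to compound 2 (0.68 log units; beyond the scatter) also changes the same ring. Replacing the bromo with chloro keeps a substituent at that place, so a smaller shift than full removal is expected, toward a higher number. The expected step is a 1.8-fold higher number from compound 2 to compound 4 (0.24 log units; within the scatter). For compound 4 the estimate is 14000 nM, within the range 5000 nM to 40000 nM.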

Compound 4, half-maximal inhibitory concentration: 45200 nM
Beside the measured number, compound 4's estimate is 3.2-fold (0.51 log units) below it; the measured number lies above the stated range.
By their numbers in this assay, from the lowest: compound 2; then compounds 1, 4 and 3 (each within the scatter of the next, the first and the last beyond it).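

In this assay chloro on this aromatic carbon does not stand in for bromo (a 5.7-fold higher number from compound 2 to compound 4 (0.75 log units; beyond the scatter)), so the two halogens are not interchangeable here. Chloro is not separated from hydrogen (a 1.7-fold lower number from compound 3 to compound 4 (0.24 log units; within the scatter)), and the 2-chlorophenyl compound is not separated from the 4-methoxyphenyl compound (a 1.2-fold higher number from compound 1 to compound 4 (0.07 log units; within the scatter)), so among the compounds shown the drop in the number at this place belongs to bromo alone. Nothing available accounts for the gap between bromo and chloro. On these data alone, whether iodo or trifluoromethyl at this place would follow bromo or chloro remains open. So does whether bromo would keep this effect at another place on the ring.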